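Benzyl for nitrophenyl on the ring nitrogen: compound 3

The compounds below may be only part of what the source reports. "The series", "measured", "known", "first", "only" and "open" are said of these compounds alone.

Compound 2 `Cc1c(C(=O)NCc2cccc(C(F)(F)F)c2)cnn1-c1ccc([N+](=O)[O-])cc1` carries a 4-nitrophenyl on the aromatic nitrogen of the shared core. Among the compounds with values here, in a functional assay on cells for antagonist activity at C-C chemokine receptor type 1 (Homo sapiens), read by FLIPR and calcium flux (on this read-out lower numbers stand for stronger inhibition and higher numbers for weaker inhibition), compound 2 gives 960 nM, the only number in the set so far. Compound 1 `Cc1c(C(=O)NCc2cccc(C(F)(F)F)c2)cnn1-c1cccc(Cl)c1`, with 3-chlorophenyl at that nitrogen, is reported only as a limit, > 3000 nM. Within the data shown here, that limit, (the limit of > 3000 nM in this assay, at which 1 of the 2 values shown sits), holds one of the two values shown, so the single measured step, an at least 3.1-fold lower number from compound 1 to compound 2 (0.49 log units; beyond the scatter), is known only as a lower bound.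

Compound 3 `Cc1c(C(=O)NCc2cccc(C(F)(F)F)c2)cnn1Cc1ccccc1` differs from compound 2 by benzyl in place of 4-nitrophenyl on an aromatic nitrogen. The step from compound 1 to compound 2 bears on this only in part: there one substituted aryl replaced another on the same nitrogen; here the nitro-bearing aryl gives way to a benzyl with no hydrogen-bond acceptors. Among the measured compounds shown here, no measured compound carries a benzyl at this position. Since compound 1, lacking the nitro group, sits at the limit > 3000 nM, a weakening is expected for compound 3. The expected step is a 3.1-fold higher number from compound 2 to compound 3 (0.49 log units; beyond the scatter). Compound 3 in this assay is estimated at 3000 nM, in a range from 900 nM to 10000 nM, with a real chance of only a limit being reported.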

Compound 3, half-maximal inhibitory concentration: > 3000 nM
Compound 3 gave a limit, no number; the forecaster's own chance of this, stated with the estimate: 50%; the middle value sits exactly at the limit.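

Benzyl in place of 4-nitrophenyl on the aromatic nitrogen gives an at least 3.1-fold higher number from compound 2 to compound 3 (0.49 log units; beyond the scatter) in this assay, so an unsubstituted benzyl here does not keep the activity seen with the nitro-bearing aryl. Compound 3 gives > 3000 nM, which is a limit and not a number. Of the groups shown at this position, only the 4-nitrophenyl of compound 2 gives a measured value, and the step between the two limit compounds, compound 1 and compound 3, cannot be read, so 3-chlorophenyl and benzyl cannot be ordered against each other: the limit of > 3000 nM in this assay, at which 2 of the 3 values shown sit.

The compounds shown do not tell whether the measured value of compound 2 depends on the nitro group itself or on an aryl bearing some other group, a question that a phenyl carrying a nitrile, an amine or a carboxylic acid on the same nitrogen would address. Also open, from the compounds shown here alone, is whether a benzyl carrying a nitro group, or a longer chain such as phenethyl, would give a number rather than a limit.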